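Dichloro to monochloro core: UO-31 cytotoxicity notes

A few compounds are considered here, and "the series" means these few. Any claim that something is new, unique, unknown or untested is made for them only; others in the source may bear on it.

Measured so far:
- compound 1, `ClCc1cccc(Cn2cnc3nc(Cl)nc(Cl)c32)c1`: 72400 nM
- compound 2, `ClCc1ccccc1Cn1cnc2c(Cl)ncnc21`: 61700 nM

In a functional assay on UO-31 cells (Homo sapiens) for cytotoxicity, read by sulforhodamine B assay, with a stated time of 48 h (a higher number here means that more compound is tolerated, a lower number that less compound is tolerated), compound 1 gives 72400 nM. Compound 2 gives 61700 nM in this assay; the two numbers sit within the scatter of each other, so compound 1 stands level with compound 2 on the values shown. Compound 3, `ClCc1cccc(Cn2cnc3ncnc(Cl)c32)c1`, is the next compound to be measured. Compared with compound 1 it carries hydrogen in place of chloro on an aromatic carbon. Among the compounds with values here, no step between measured compounds covers this change, so the expected step from compound 1 to compound 3 is a 1.1-fold lower number from compound 1 to compound 3 (0.05 log units; within the scatter), within the scatter, with no clear direction. For compound 3 the estimate in this assay is 65000 nM, expected between 30000 nM and 140000 nM.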

Compound 3, concentration lethal to 50% of the cells: 26900 nM
Beside the measured number, compound 3's estimate is 2.4-fold (0.38 log units) above it; measured number outside the range, below it.
By their numbers in this assay, from the lowest: compound 3; then compounds 2 and 1 (each within the scatter of the next).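

Swapping the chloro group for hydrogen on the aromatic carbon between two ring nitrogen atoms gives the first readable single-place step in the series: in this assay there is a 2.7-fold lower number from compound 1 to compound 3 (0.43 log units; beyond the scatter), beyond the scatter. Less compound is tolerated with hydrogen at this position, although only this one pair shows it. No measured evidence bears on the reason for this step.

Still open, going by these compounds, is how an amine or a methoxy group on this carbon would read. Also open, on these data alone, is whether the step recurs on a core other than that of compound 1.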